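From 4-Methoxyphenyl to 3-Hydroxyphenyl on a Shared Core

The source may report more compounds than this note shows. Statements on the series, on what has been measured and on what is new or still open speak of the compounds shown alone.

compound 1 `COC(=O)N1N=C(c2ccccc2)CC1c1cc(OC)c(OC)c(OC)c1` gives 2770 nM
compound 2 `COC(=O)N1N=C(c2cccc(OC)c2)CC1c1cc(OC)c(OC)c(OC)c1` gives 2780 nM
compound 3 `COC(=O)N1N=C(c2ccc(OC)cc2)CC1c1cc(OC)c(OC)c(OC)c1` gives 5000 nM

In a functional assay on A2780 cells (Homo sapiens) for antiproliferative activity, read by MTT assay, with a stated time of 48 h (on this read-out higher numbers stand for weaker inhibition of growth and lower numbers for stronger inhibition of growth), these values sit close together: compound 3 lies within the scatter of both others (a 1.8-fold higher number from compound 1 to compound 3 (0.26 log units; within the scatter)) and (a 1.8-fold higher number from compound 2 to compound 3 (0.25 log units; within the scatter)) so nothing separates the three.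

Among the compounds with values here, compound 4 `COC(=O)N1N=C(c2cccc(O)c2)CC1c1cc(OC)c(OC)c(OC)c1` carries 3-hydroxyphenyl in place of 4-methoxyphenyl on a carbon with a double bond to nitrogen and no measured compound carries this group. The closest guide is compound 2 with its 3-methoxyphenyl group and its value of 2780 nM as a reference point. Swapping groups on this phenyl ring has so far moved little (a 1.0-fold higher number from compound 1 to compound 2 (0.00 log units; within the scatter)) and (a 1.8-fold higher number from compound 2 to compound 3 (0.25 log units; within the scatter)) so no step beyond the scatter in this assay is expected, with a slight lean toward a lower number. The expected step is (a 1.4-fold lower number from compound 3 to compound 4 (0.15 log units; within the scatter)) and it stays small. Compound 4 is estimated at 3500 nM with an expected range from 1500 nM to 8000 nM around that figure.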

Compound 4, concentration for 50% growth inhibition: 810 nM
Compound 4: middle estimate off by 4.3-fold (0.64 log units), on the high side; measured number below the stated range.
By their numbers in this assay, from the lowest: compound 4; then compounds 1, 2 and 3 (each within the scatter of the next).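

Within the data shown here, the hydroxy group on the phenyl ring brings the first steps beyond the scatter at this position in this assay (a 3.4-fold lower number from compound 1 to compound 4 (0.53 log units; beyond the scatter)) (a 3.4-fold lower number from compound 2 to compound 4 (0.54 log units; beyond the scatter)) (a 6.2-fold lower number from compound 3 to compound 4 (0.79 log units; beyond the scatter)). Methoxy in place of hydrogen gave no such step, but hydrogen in place of the methyl on that same oxygen does, so a hydroxy and a methoxy on this ring are not interchangeable here. Nothing measured here explains the lower number. The compounds shown leave open whether this step belongs to the hydroxy group alone or would also come with an amine or a carboxylic acid on that ring.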